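A urea in place of an amide: compound 1 to compound 4

The source may hold more compounds than are shown below. What is called first, only, known or untested is meant among the compounds shown, and "the series" means these compounds.

Compound 1, `COc1cc(-c2nn(-c3cccc(NC(=O)c4ccc(Cl)c(C(F)(F)F)c4)c3)cc2-c2ccncc2)ccc1Cl`, was tested in a functional assay on OVCAR-4 cells (Homo sapiens) for inhibition, read by sulforhodamine B assay, with a stated time of 48 h; a higher number here means a weaker inhibitor of growth, a lower number a stronger inhibitor of growth. In this assay compound 1 gives > 32500 nM, which is a limit of the assay rather than a measured number. Its standing among the values shown is therefore only that of a limit; the same holds for (the limit of > 32500 nM in this assay, at which 2 of the 3 values shown sit). Compound 2, `O=C(Nc1cccc(-n2cc(-c3ccncc3)c(-c3ccc(Cl)c(O)c3)n2)c1)Nc1cc(C(F)(F)F)cc(C(F)(F)F)c1`, gives 5010 nM in this assay. Compound 3, `O=C(Nc1cccc(-n2cc(-c3ccncc3)c(-c3ccc(Cl)c(O)c3)n2)c1)Nc1ccc(Cl)c(C(F)(F)F)c1`, gives > 32500 nM in this assay, again a limit and not a number. No pair among these three differs in a single place, so no measured step is available.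

Compound 4, `COc1cc(-c2nn(-c3cccc(NC(=O)Nc4ccc(Cl)c(Cl)c4)c3)cc2-c2ccncc2)ccc1Cl`, has not yet been measured. It differs from compound 1 by (3,4-dichlorophenyl)amino in place of 4-chloro-3-(trifluoromethyl)phenyl on a carbonyl carbon. The change replaces the directly attached aryl ring with an aryl amine, turning the amide into a urea, and exchanges trifluoromethyl for a second chlorine.

Because compound 1 sits at > 32500 nM, any step can only be judged from a limit. For this assay a step from compound 1 to compound 4 is expected to be small or none beyond the scatter, and compound 4 is expected to give about 25000 nM, with a range from 8000 nM to 32500 nM, quite possibly reported again as a limit.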

Compound 4, concentration for total growth inhibition: > 50000 nM
Compound 4 ended at the assay's limit (the forecaster's own chance of this, stated with the estimate: 60%); middle value at least 2.0-fold (0.30 log units) from the limit.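

In this assay compound 4 gives > 50000 nM, a limit of the assay and not a number. Among these compounds, compound 1 gives > 32500 nM, also a limit, so no step from compound 1 to compound 4 can be read. The compounds shown leave open whether exchanging 4-chloro-3-(trifluoromethyl)phenyl for (3,4-dichlorophenyl)amino changes growth inhibition at all.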